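A few compounds are considered here, and "the series" means these few. Any claim that something is new, unique, unknown or untested is made for them only; others in the source may bear on it.

- compound 1 `N#C/C(=C\c1cn(Cc2ccc(Cl)cc2)c2ccccc12)C(=O)c1c[nH]c2cc(F)ccc12` gives > 50000 nM in a functional assay on PC-3 cells (Homo sapiens) for cytotoxicity, read by WST assay, with a stated time of 48 h; a lower number here means a stronger inhibitor, a higher number a weaker inhibitor
- compound 2 `COc1ccc(Cn2cc(/C=C(\C#N)C(=O)c3c[nH]c4cc(OC)ccc34)c3ccccc32)cc1` gives > 50000 nM in this assay

Compound 2 reads > 50000 nM in this assay, which is a limit and not a number. Among the compounds with values here, the picture so far is the limit of > 50000 nM in this assay, at which 2 of the 2 values shown sit, and no measured pair differs in one place only.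

Compound 3 `COc1ccc(Cn2cc(/C=C(\C#N)C(=O)c3c[nH]c4cc(F)ccc34)c3ccccc32)cc1` has fluoro in place of methoxy on an aromatic carbon, so that 6-methoxy-1H-indol-3-yl becomes 6-fluoro-1H-indol-3-yl (fluoro in place of methoxy on an aromatic carbon). Compound 1, which also holds the 6-fluoro-1H-indol-3-yl group, gives only a limit, > 50000 nM, so no step beyond the scatter is expected in this assay, in either direction. The expected step is a number no higher from compound 2 to compound 3 (the limit leaves the size open), and compound 3 may well report only a limit too. For compound 3 the estimated value is 50000 nM, with an expected range from 20000 nM to 100000 nM.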

Compound 3, half-maximal inhibitory concentration: > 50000 nM
Compound 3 ended at the assay's limit; the forecaster's own chance of this, stated with the estimate: 85%; the middle value sits exactly at the limit.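

In this assay compound 3 gives > 50000 nM and this is a limit, not a number. No step can be read from compound 2 to compound 3 or from compound 1 to compound 3, since all three compounds share one limit: the limit of > 50000 nM in this assay, at which 3 of the 3 values shown sit. On these data alone, how far these three compounds truly differ in strength stays open.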